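Clearance notes: 4-fluorophenyl to 2,4-dichlorophenyl

A few compounds are considered here, and "the series" means these few. Any claim that something is new, unique, unknown or untested is made for them only; others in the source may bear on it.

Of the compounds shown here, two with a shared core have numbers so far in an in vitro ADME assay on microsomes from liver (Homo sapiens) for metabolic stability; on this read-out higher numbers stand for fast clearance and lower numbers for slow clearance. Compound 1 (`O=C(COCc1ccccc1)N1CCN(c2ccccc2Cl)CC1`) gives 540 mL.min-1.g-1, and compound 2 (`O=C(COCc1ccccc1)N1CCN(c2ccc(F)cc2)CC1`) gives 110 mL.min-1.g-1, the lower of the two numbers. Among the measured compounds shown here, compound 3 (`O=C(COCc1ccccc1)N1CCN(c2ccc(Cl)cc2Cl)CC1`) has no measurement yet.

Its difference from compound 2 is 2,4-dichlorophenyl in place of 4-fluorophenyl on an amine nitrogen in a ring. For the measured compounds named here, one measured step bears on this change: a 4.9-fold lower number from compound 1 to compound 2 (0.69 log units; beyond the scatter), with 4-fluorophenyl in place of 2-chlorophenyl at the same place. That step is modest and beyond the scatter. Going by the values given here, with only one step available, the second chlorine of compound 3 has no measured counterpart, so the reasoning is thin. Compound 1, at 540 mL.min-1.g-1, is taken as the closer reference. It also carries a chlorophenyl group.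

The expected change is a 4.1-fold higher number from compound 2 to compound 3 (0.61 log units; beyond the scatter), a move toward a higher number in this assay, close in size to the measured step taken in reverse. For compound 3 the estimate is 450 mL.min-1.g-1, with an expected range from 180 mL.min-1.g-1 to 1000 mL.min-1.g-1.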

Compound 3, intrinsic clearance in microsomes: 450 mL.min-1.g-1
Estimate against measurement, compound 3: no gap at the digits printed; measured number inside the range.
By their numbers in this assay, from the lowest: compound 2; then compounds 3 and 1 (each within the scatter of the next).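

In this assay, among the compounds shown here, the exchange of 4-fluorophenyl for 2,4-dichlorophenyl on the amine nitrogen in the ring gives a 4.1-fold higher number from compound 2 to compound 3 (0.61 log units; beyond the scatter) and thus shows that compound 2 stands apart from a second chlorinated partner as well as from compound 1, which until now was the only comparison. The new information lies in the other step, where chloro in place of hydrogen on an aromatic carbon gives a 1.2-fold lower number from compound 1 to compound 3 (0.08 log units; within the scatter) so that the second chlorine on the aryl group brings no change that can be read on this clearance measure, and compounds 1 and 3 stand level within the scatter. Nothing available gives a reason for either step.

Compound 2 differs from compounds 1 and 3 both in carrying fluorine instead of chlorine and in lacking the chlorine of the 2-chlorophenyl group, so these compounds cannot show which of those differences goes with its lower number. A plain phenyl, a 4-chlorophenyl or a 2-fluorophenyl group on the same nitrogen would separate the two readings.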